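Amide variation on the amine-linked series: volume of distribution

This account rests on a few compounds, and the source may have more. Where it says the series, first, only, none or still open, it means among the compounds named here.

Going by the values given here, in an ADME assay (Rattus norvegicus, strain Wistar Han) for pharmacokinetics (a higher number here means that more of the compound sits outside the plasma, a lower number that more of the compound stays in the plasma), compound 1 `CCn1c(-c2cnc(C)nc2)nc2c(N[C@H]3CCN(C(=O)C4CC(F)(F)C4)C3)ncnc21` gives 18 L/kg, the higher of the two numbers measured so far. Compound 2 `CCn1c(-c2cnc(C)nc2)nc2c(O[C@H]3CCN(C(=O)C4CCOC4)C3)ncnc21` gives 0.9 L/kg in this assay; the two compounds differ in more than one place, so the gap between them says only what the two values show. Compound 3 `CCn1c(-c2cnc(C)nc2)nc2c(N[C@H]3CCN(C(=O)C4CC4)C3)ncnc21` has not yet been measured in this assay. It differs from compound 1 in one place: cyclopropyl in place of 3,3-difluorocyclobutyl on a carbonyl carbon. Among the compounds with values here, no step between measured compounds covers this change on its own, so the expectation rests on compound 1, whose value of 18 L/kg anchors the estimate. A modest downward step is expected, a 1.8-fold lower number from compound 1 to compound 3 (0.26 log units; within the scatter), of a size that may still sit within the usual scatter. Compound 3 is accordingly estimated to give 10 L/kg in this assay, with an expected range from 4 L/kg to 28 L/kg.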

Compound 3, volume of distribution: 6.3 L/kg
The estimate for compound 3 lay 1.6-fold (0.20 log units) above the measured number, and the stated range covers the measured number.
By their numbers in this assay, from the lowest: compound 2; then compound 3; then compound 1.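

With the rest of the molecule held fixed, the group on the carbonyl carbon alone moves the number in this assay: cyclopropyl in place of 3,3-difluorocyclobutyl gives a 2.9-fold lower number from compound 1 to compound 3 (0.46 log units; beyond the scatter) and so a step that is modest but clears the scatter. Going by these compounds alone, this is the first single-place comparison, and it shows that this position can shift the read-out, so part of the high value of compound 1 goes with its 3,3-difluorocyclobutyl group. Nothing available bears on the reason for this step.

Left open is whether the step follows the two fluorine atoms or the ring size, which a plain cyclobutyl on the same carbonyl carbon would separate. Also open, as far as these compounds go, is whether the same change gives a similar step with the oxygen link of compound 2 in place of the amine link.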